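The compounds below may be only part of what the source reports. "The series", "measured", "known", "first", "only" and "open" are said of these compounds alone.

Compound 1 `C#C[C@H](CC(=O)O)NC(=O)CN1CCc2ccc(N3CCNCC3)cc2C1=O`: 12 nM
Compound 2 `O=C(O)C[C@H](NC(=O)CN1CCc2ccc(N3CCNCC3)cc2C1=O)C1=CC=CN(O)C1`: 18 nM
Compound 3 `C#C[C@H](CC(=O)O)NC(=O)CN1CCc2cc(F)c(N3CCNCC3)cc2C1=O`: 15 nM

In a functional assay for inhibition, with Homo sapiens as the target (a higher number here means a weaker inhibitor, a lower number a stronger inhibitor), compound 3 gives 15 nM, a value that cannot be told apart from those of compound 1 and compound 2. Compound 4 `C#C[C@H](CC(=O)O)NC(=O)CN1CCc2cc(Cl)c(N3CCNCC3)cc2C1=O` carries chloro in place of fluoro on an aromatic carbon, ortho to a piperazin-1-yl group: chloro in place of fluoro on an aromatic carbon. The closest measured guide is fluoro in place of hydrogen on an aromatic carbon, a 1.3-fold higher number from compound 1 to compound 3 (0.10 log units; within the scatter). The other measured step, a 1.5-fold higher number from compound 1 to compound 2 (0.18 log units; within the scatter), lies on a saturated chain carbon and says little here. Among the compounds with values here, no chloro compound has been measured yet, so no step beyond the scatter is expected. The expected change is a 1.1-fold higher number from compound 3 to compound 4 (0.03 log units; within the scatter). For compound 4 the estimate is 16 nM, with an expected range of 7 nM to 35 nM.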

Compound 4, half-maximal inhibitory concentration: 19 nM
The estimate for compound 4 lay 1.2-fold (0.07 log units) below the measured number; low and high end bracket the measured number.
By their numbers in this assay, from the lowest: compounds 1, 3, 2 and 4 (each within the scatter of the next).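

In this assay, this position, ortho to a piperazin-1-yl group, now takes chloro as well as fluoro with no change that can be told from the scatter: chloro in place of fluoro gives (a 1.3-fold higher number from compound 3 to compound 4 (0.10 log units; within the scatter)), and chloro in place of hydrogen gives (a 1.6-fold higher number from compound 1 to compound 4 (0.20 log units; within the scatter)). Hydrogen, fluoro and chloro therefore cannot be separated here, and no measurement at hand explains this. As far as these compounds go, whether a methyl, methoxy or nitrile group here would also stay within the scatter remains open. So does whether chloro would behave the same on another aromatic carbon of the core.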